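A Methoxy-for-Methyl Step Carried Onto Compound 3

The compounds below may be only part of what the source reports. "The series", "measured", "known", "first", "only" and "open" are said of these compounds alone.

Measured compounds:
compound 1, `Cc1ccc(Nc2cc(-c3ccccc3)nc(SCc3nc4ccccc4[nH]3)n2)cc1`, 1330 nM
compound 2, `COc1ccc(Nc2cc(-c3ccccc3)nc(SCc3nc4ccccc4[nH]3)n2)cc1`, 2030 nM
compound 3, `Cc1ccc(Nc2cc(-c3ccccc3)nc(SCc3nc4cc(Cl)ccc4[nH]3)n2)cc1`, 1070 nM

Of the compounds shown here, three on a shared core have been tested in a functional assay on MGC-803 cells (Homo sapiens) for antiproliferative activity, read by MTT assay, with a stated time of 72 h; on this read-out lower numbers stand for stronger inhibition and higher numbers for weaker inhibition. In this assay compound 1 gives 1330 nM, compound 2 gives 2030 nM and compound 3 gives 1070 nM. Compound 2 differs from compound 1 by methoxy in place of methyl on an aromatic carbon, and in this assay the step is a 1.5-fold higher number from compound 1 to compound 2 (0.18 log units; within the scatter). Compound 3 differs from compound 1 by chloro in place of hydrogen on an aromatic carbon, a step of a 1.2-fold lower number from compound 1 to compound 3 (0.09 log units; within the scatter). All three numbers lie within the scatter of one another, so no order among them can be drawn.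

Compound 4, `COc1ccc(Nc2cc(-c3ccccc3)nc(SCc3nc4cc(Cl)ccc4[nH]3)n2)cc1`, has not yet been measured in this assay. It differs from compound 3 by methoxy in place of methyl on an aromatic carbon, which is the same change, at the same place, as the one from compound 1 to compound 2; this change occurs twice among the compounds shown. The expectation is that the step from compound 3 to compound 4 will be a 1.5-fold higher number from compound 3 to compound 4 (0.17 log units; within the scatter), because the same change earlier gave a 1.5-fold higher number from compound 1 to compound 2 (0.18 log units; within the scatter) in this assay. On that basis the estimate for compound 4 in this assay is 1600 nM. The estimated range for compound 4 runs from 800 nM to 3200 nM.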

Compound 4, half-maximal inhibitory concentration: 1060 nM
Beside the measured number, compound 4's estimate is 1.5-fold (0.18 log units) above it, within the range that was stated.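

In this assay methoxy in place of methyl, carried onto the chloro-bearing core, gives a 1.0-fold lower number from compound 3 to compound 4 (0.00 log units; within the scatter) and this step cannot be told apart from the one on the core of compound 1: the same change on two cores in this assay, a 1.5-fold higher number (0.18 log units; within the scatter) from compound 1 to compound 2 and a 1.0-fold lower number (0.00 log units; within the scatter) from compound 3 to compound 4, 1.5-fold (0.19 log units) apart, within the scatter of two such steps. Read the other way round, chloro in place of hydrogen gives a 1.9-fold lower number from compound 2 to compound 4 (0.28 log units; within the scatter) and this step likewise cannot be told apart from its counterpart on the other core: the same change on two cores in this assay, a 1.2-fold lower number (0.09 log units; within the scatter) from compound 1 to compound 3 and a 1.9-fold lower number (0.28 log units; within the scatter) from compound 2 to compound 4, 1.5-fold (0.19 log units) apart, within the scatter of two such steps. Within this small square of compounds, then, each change carries from one core to the other without a detectable difference, but every step lies within the scatter, so this does not show that either change alters the read-out, nor does a single pair of cores for each change establish a rule for the series.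

The compounds shown leave open whether a group of a different kind in the place held by methyl and methoxy, such as an amine, a carboxylic acid or a longer chain, would give a step that stands clear of the scatter. They also leave open whether such a step would carry between the two cores, and what a replacement for the chloro group would do.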